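This account rests on a few compounds, and the source may have more. Where it says the series, first, only, none or still open, it means among the compounds named here.

Measured compounds:
Compound 1 `CC(C)N(Cc1cccc(OCCCCCC(=O)O)c1)C(=O)c1ccc(-c2cccc(-c3ccccc3)c2)cc1` — in an ADME assay on BJ cells (Homo sapiens) for cytotoxicity, read by CellTiter-Glo and resazurin assay, with a stated time of 72 h (a higher number here means that more compound is needed for the effect, a lower number that less compound is needed), compound 1 gives > 26000 nM, which is a limit of the assay.
Compound 2 `CC(C)Oc1cccc(-c2ccc(C(=O)N(Cc3cccc(OCCCCCC(=O)O)c3)C(C)C)cc2)c1` — in this assay compound 2 gives > 26000 nM, also a limit.
Compound 3 `CC(C)N(Cc1cccc(OCCCCCC(=O)O)c1)C(=O)c1ccc(-c2ccsc2)cc1` — in this assay compound 3 gives > 26000 nM, again a limit.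

Compound 3 therefore stands nowhere in particular among the numbers shown: all three values sit at the same limit (the limit of > 26000 nM in this assay, at which 3 of the 3 values shown sit), and none of the steps between them can be read. The step from compound 1 to compound 3 is a step that the two limits leave unreadable from compound 1 to compound 3, and the step from compound 2 to compound 3 is a step that the two limits leave unreadable from compound 2 to compound 3.

Compound 4 `CC(C)N(Cc1cccc(OCCCCCC(=O)O)c1)C(=O)c1ccc(-c2ccc3c(c2)OCCO3)cc1` differs from compound 3 by 2,3-dihydro-1,4-benzodioxin-6-yl in place of thiophen-3-yl on an aromatic carbon. Among the measured compounds shown here, the only steps that bear on this change are those two unreadable ones, so no size or direction can be expected beyond a limit. Compound 4 is therefore expected to give 30000 nM, in a range from 12000 nM to 80000 nM, most likely reported as a limit. The estimated step that the limit leaves unreadable from compound 3 to compound 4 is expected to be nothing readable.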

Compound 4, half-maximal effective concentration: > 21900 nM
Compound 4 ended at the assay's limit; the forecaster's own chance of this, stated with the estimate: 85%; the middle value lies beyond the limit too.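

In this assay compound 4 gives > 21900 nM, a limit of the assay. No step from compound 1, compound 2 or compound 3 to compound 4 can be read, as those three also sit at a limit: the limit of > 26000 nM in this assay, at which 3 of the 4 values shown sit.

The compounds shown leave open whether any group at this aromatic carbon alters cytotoxicity, and at what concentration any of the four would reach the effect.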